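Following a Side Chain Swap from Compound 2

The source may hold more compounds than are shown below. What is called first, only, known or untested is meant among the compounds shown, and "the series" means these compounds.

Compound 1 `Nc1cccc(C2=NNC(=O)CC2)c1` gives > 46.4 ug/mL as a limit of the assay
Compound 2 `CC(Cl)C(=O)Nc1ccc(C2=NNC(=O)CC2)cc1` gives 0.45 ug/mL
Compound 3 `CC1CC(c2ccc(NC(=O)CCl)cc2)=NNC1=O` gives 21.9 ug/mL

These results come from a functional assay for inhibition, with Homo sapiens as the target (on this read-out lower numbers stand for an effect already at smaller amounts and higher numbers for an effect only at larger amounts of compound), and are the only ones available so far. Compound 1 has the value > 46.4 ug/mL, which is a limit and not a number. Compound 2 gives 0.45 ug/mL, the lower of the two true numbers, and compound 3 gives 21.9 ug/mL, a gap well beyond the usual scatter.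

The next compound to be tested is compound 4 `C=CCNCC(=O)Nc1ccc(C2=NNC(=O)CC2)cc1`. It carries (allylamino)methyl in place of 1-chloroethyl on a carbonyl carbon. Among the measured compounds shown here, no measured pair here differs in just one place, so no direct precedent exists for this swap. The expectation therefore rests on the spread of the values alone. Compound 2 at 0.45 ug/mL already sits low, while compound 3 at 21.9 ug/mL shows how much higher a close relative can lie. A clear move toward a higher number is thus the likelier outcome, though the size is uncertain. The expected change is an 11-fold higher number from compound 2 to compound 4 (1.05 log units; beyond the scatter) in this assay. For compound 4 the estimated value is 5 ug/mL, with an expected range from 0.6 ug/mL to 40 ug/mL as its ends.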

Compound 4, half-maximal effective concentration: about 21.5 ug/mL
Compound 4: middle estimate off by 4.3-fold (0.63 log units), on the low side; the range from low to high includes it.
By their numbers in this assay, from the lowest: compound 2; then compounds 4 and 3 (each within the scatter of the next). At a limit, above all of these: compound 1.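

In this assay, putting (allylamino)methyl in place of 1-chloroethyl on a carbonyl carbon gives a 48-fold higher number from compound 2 to compound 4 (1.68 log units; beyond the scatter). Among the compounds shown here, this is the first pair here that differs in just one place, so it offers the first direct sign that the group on this carbonyl carbon, whose other neighbour is an amide-type nitrogen, can strongly shift the read-out, and this swap moves it toward a higher number. Only compound 1 stands at a limit, so this step is a full reading and not a cut-off one: the limit of > 46.4 ug/mL in this assay, at which 1 of the 4 values shown sits.

The swap changes several things at once, since the chlorine leaves while a nitrogen, a double bond and a longer chain enter, and this single step cannot show which of these matters. A plain ethyl group would test the loss of chlorine alone, while a propylaminomethyl group would test the double bond, and a carboxylic acid or a longer chloroalkyl chain at the same place would show how far the trend extends.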